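A few compounds are considered here, and "the series" means these few. Any claim that something is new, unique, unknown or untested is made for them only; others in the source may bear on it.

Of the compounds shown here, three sharing one core have been measured in a functional assay on CHO-K1 cells for antagonist activity at prostaglandin E2 receptor EP1 subtype (Homo sapiens), read by FLIPR and calcium flux; on this read-out lower numbers stand for stronger inhibition and higher numbers for weaker inhibition. Compound 1 `CCc1ccccc1N(CC(=O)NCc1cccc(OC)c1)S(=O)(=O)c1ccc(C)cc1` gives 138 nM. Compound 2 `CCc1ccccc1N(CC(=O)NCc1cccc(OC(F)(F)F)c1)S(=O)(=O)c1ccc(C)cc1` gives 427 nM. Compound 3 `CCc1ccccc1N(CC(=O)NCc1ccccc1F)S(=O)(=O)c1ccc(C)cc1` gives 135 nM. Compound 3 holds the lowest of the three numbers, but its neighbour is compound 1, and the step of a 1.0-fold lower number from compound 1 to compound 3 (0.01 log units; within the scatter) lies within the scatter, so the two cannot be ordered; only compound 2 stands apart, with a 3.2-fold lower number from compound 2 to compound 3 (0.50 log units; beyond the scatter) and a 3.1-fold higher number from compound 1 to compound 2 (0.49 log units; beyond the scatter).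

The next compound, compound 4 `CCc1ccccc1N(CC(=O)NCc1ccccc1OC)S(=O)(=O)c1ccc(C)cc1`, differs from compound 3 by methoxy in place of fluoro on an aromatic carbon. Going by the values given here, no measured pair swaps fluoro for methoxy at the same spot. Among the compounds with values here, the nearest guidance is the step of a 1.0-fold lower number from compound 1 to compound 3 (0.01 log units; within the scatter), where a fluorinated benzyl and a methoxylated benzyl gave numbers that cannot be told apart, and the step of a 3.1-fold higher number from compound 1 to compound 2 (0.49 log units; beyond the scatter), which is the only change on the benzyl ring that moved the read-out beyond the scatter. On that basis the expectation for this assay is no step beyond the scatter, in either direction, from compound 3 to compound 4, the expected step being a 1.1-fold higher number from compound 3 to compound 4 (0.05 log units; within the scatter). Compound 4 is therefore estimated at 150 nM, with an expected range from 60 nM to 400 nM.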

Compound 4, inhibition constant: 1070 nM
Compound 4: the middle estimate sits 7.1-fold (0.85 log units) below what was measured; measured number above the stated range.
By their numbers in this assay, from the lowest: compounds 3 and 1 (each within the scatter of the next); then compound 2; then compound 4.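

In this assay the aromatic carbon ortho to a large group proves sensitive to its substituent: methoxy in place of fluoro gives a 7.9-fold higher number from compound 3 to compound 4 (0.90 log units; beyond the scatter) and so separates two groups at one spot, although 2-fluorobenzyl and 3-methoxybenzyl could not be told apart earlier. The location of the methoxy group on the ring also matters, since 2-methoxyphenyl in place of 3-methoxyphenyl gives a 7.8-fold higher number from compound 1 to compound 4 (0.89 log units; beyond the scatter) while 2-methoxyphenyl in place of 3-(trifluoromethoxy)phenyl gives a 2.5-fold higher number from compound 2 to compound 4 (0.40 log units; beyond the scatter) and carries the number past that of compound 2, previously the highest of the series. No evidence is available that would account for this result.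

The compounds shown leave open whether the step follows the oxygen or the methyl carbon of the methoxy group, which a hydroxyl, methyl or ethoxy group on the same aromatic carbon could help to separate. On these data alone, it is also open how 3-fluorophenyl would read against 2-fluorophenyl, and whether an amine or a chlorine at that carbon would stay with compound 3 or move towards compound 4.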